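A few compounds are considered here, and "the series" means these few. Any claim that something is new, unique, unknown or untested is made for them only; others in the source may bear on it.

Compound 1 `Cc1cc(C(=O)Nc2ccccn2)nn1Cc1cc(Cl)ccc1OCc1ccccc1` was measured in a physicochemical assay for lipophilicity, at pH 7.4 (a lower number here means a more polar compound, a higher number a more lipophilic compound), where compound 1 gives > 3.7, a limit of the assay rather than a number. Compound 2 `Cc1cc(C(=O)NCc2cccnc2)nn1Cc1cc(Cl)ccc1OCc1ccccc1` likewise gives a limit in this assay, > 3.7. Compound 3 `Cc1cc(NC(=O)C(C)C)nn1Cc1cc(Cl)ccc1OCc1ccccc1` also reaches a limit in this assay, > 3.7. The steps between them, a step that the two limits leave unreadable from compound 1 to compound 2 and a step that the two limits leave unreadable from compound 1 to compound 3, cannot be sized, because all three values sit at the limit of > 3.7 in this assay, at which 3 of the 3 values shown sit. Compound 4 `Cc1cc(NC(=O)OCc2ccccc2)nn1Cc1cc(Cl)ccc1OCc1ccccc1` differs from compound 1 in one place: (benzyloxycarbonyl)amino in place of (pyridin-2-yl)carbamoyl on an aromatic carbon. With no readable step among the three measured compounds, no direction can be expected, and compound 4 is expected to reach the same limit, so the step that the limit leaves unreadable from compound 1 to compound 4 is an estimate only. Compound 4 is estimated at 4.5, between 3.8 and 5.3.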

Compound 4, distribution coefficient: 3.1
Estimate against measurement, compound 4: 1.40 log units above; measured number outside the range, below it.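

Going by these compounds alone, compound 4 gives the only readable number at this position in this assay, which shows a number at least 0.60 log units lower from compound 1 to compound 4 (beyond the scatter), a number at least 0.60 log units lower from compound 2 to compound 4 (beyond the scatter) and a number at least 0.60 log units lower from compound 3 to compound 4 (beyond the scatter). Benzyloxy in place of isopropyl on a carbonyl carbon is a change in one place, and (benzyloxycarbonyl)amino gives the lower number despite having 11 heavy atoms against 9 in (pyridin-2-yl)carbamoyl. The true size of each step stays unknown, as each starts from a limit: the limit of > 3.7 in this assay, at which 3 of the 4 values shown sit.

The steps among compound 1, compound 2 and compound 3 cannot be read. Going by these compounds, whether a free amine or a carboxylic acid at this position would give a still lower number remains open.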